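The source may hold more compounds than are shown below. What is called first, only, known or untested is meant among the compounds shown, and "the series" means these compounds.

Compound 1 `CCC(=O)NNC(=O)c1csc2ncc(-c3ccc(C)cc3)n12`: 9230 nM
Compound 2 `CC(=O)NNC(=O)c1csc2ncc(-c3ccc(Br)cc3)n12`: 6080 nM

In a functional assay on HCT-116 cells (Homo sapiens) for antiproliferative activity, read by MTT assay, with a stated time of 72 h (a lower number here means a stronger inhibitor, a higher number a weaker inhibitor), compound 2 gives 6080 nM and compound 1 gives 9230 nM, two numbers within the usual scatter of each other. Compound 3 `CCC(=O)NNC(=O)c1csc2ncc(-c3ccc(Br)cc3)n12` differs from compound 2 in one place: methyl in place of hydrogen on a saturated chain carbon bound to a carbonyl carbon, so acetyl becomes propanoyl. Among the measured compounds shown here, no measured pair shows this change alone, since compound 1 also differs elsewhere. Still, compound 1, which carries propanoyl, sits at 9230 nM, so no step beyond the scatter is expected. The estimated change is a 1.1-fold higher number from compound 2 to compound 3 (0.03 log units; within the scatter). For compound 3 the expected value is 6500 nM, with an estimated range from 3000 nM to 14000 nM.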

Compound 3, half-maximal inhibitory concentration: 25300 nM
The estimate for compound 3 lay 3.9-fold (0.59 log units) below the measured number; measured number above the stated range.
By their numbers in this assay, from the lowest: compounds 2 and 1 (each within the scatter of the next); then compound 3.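

In this assay a single methyl on the saturated chain carbon bound to a carbonyl carbon matters: with the bromo group held fixed, acetyl to propanoyl gives a 4.2-fold higher number from compound 2 to compound 3 (0.62 log units; beyond the scatter) and so a weaker inhibitor. The aromatic carbon matters too: with propanoyl held fixed, bromo in place of methyl gives a 2.7-fold higher number from compound 1 to compound 3 (0.44 log units; beyond the scatter) and again a weaker inhibitor. No measurement here explains either step. From the compounds shown here alone, whether a longer chain such as butanoyl, or an amine on that chain carbon, would raise the number further remains open.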